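Sulfonamide Antiproliferatives: Trading a Methylphenyl for Naphthyl

The compounds below may be only part of what the source reports. "The series", "measured", "known", "first", "only" and "open" are said of these compounds alone.

Measured compounds:
- Compound 1, `Cc1cc(C)c(S(=O)(=O)N2CCN(C3CN4CCC3CC4)CC2)c(C)c1`: 84 nM
- Compound 2, `Cc1ccc(-c2cccc(S(=O)(=O)N3CCC(N4CCC(C)CC4)CC3)c2)cc1`: 11 nM

Both compounds were tested in a functional assay on DLD-1 cells (Homo sapiens) for antiproliferative activity, read by CellTiter-Glo, with a stated time of 72 h; on this read-out higher numbers stand for weaker inhibition and lower numbers for stronger inhibition. Compound 1 gives 84 nM, while compound 2 gives 11 nM, the lower of the two numbers, and the gap between them lies beyond the usual scatter. Compound 2 therefore stands as the stronger inhibitor of the pair on these data.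

The next compound, compound 3, `CC1CCN(C2CCN(S(=O)(=O)c3cccc(-c4ccc5ccccc5c4)c3)CC2)CC1`, keeps the whole core of compound 2 and changes one group: naphthalen-2-yl in place of 4-methylphenyl on an aromatic carbon. Within the data shown here, no pair of measured compounds shows this kind of swap, so the size of the effect is unknown from the numbers at hand.

With the rest of compound 2 untouched, compound 3 is expected to stay close to compound 2, with a step of a 1.1-fold higher number from compound 2 to compound 3 (0.04 log units; within the scatter) that is likely within or near the usual scatter. The estimated value for compound 3 is 12 nM, with a plausible range from 4 nM to 40 nM.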

Compound 3, half-maximal inhibitory concentration: 2 nM
Compound 3: the middle estimate sits 6.0-fold (0.78 log units) above what was measured; measured number outside the range, below it.
By their numbers in this assay, from the lowest: compound 3; then compound 2; then compound 1.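

Replacing 4-methylphenyl with naphthalen-2-yl gives a 5.5-fold lower number from compound 2 to compound 3 (0.74 log units; beyond the scatter) in this assay, so this position, meta to a large group, is sensitive to the aromatic group it carries and tolerates a larger one, which here goes with stronger inhibition. The change adds a second six-membered aromatic ring of carbon only while the count of hydrogen-bond donors and acceptors stays at zero, but this rests on a single pair and is no general trend. No measurement is available that would explain why compound 3 gives the lower number.

The compounds shown leave open how other groups at this position would behave, such as a pyridine ring, a carboxylic acid or a simple phenyl ring. They also leave open whether naphthalen-2-yl would give a similar step on a different core.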